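The source may report more compounds than this note shows. Statements on the series, on what has been measured and on what is new or still open speak of the compounds shown alone.

Three compounds sharing one core and differing only in the group attached to an aromatic carbon have been measured in an ADME assay on the whole organism (Rattus norvegicus), at a dose of 2 mg/kg by the oral route; a higher number here means more compound in the circulation at the dose given, a lower number less compound in the circulation. Compound 1 `COc1cc(OCc2cccc(-c3ccc(C(F)(F)F)cn3)c2)c2cc(-c3cn4nc(OC)sc4n3)oc2c1` gives 459 ng.h/mL, compound 2 `COc1cc(OCc2cccc(-c3ccc(OC)nc3)c2)c2cc(-c3cn4nc(OC)sc4n3)oc2c1` gives 1800 ng.h/mL, and compound 3 `COc1cc(OCc2cccc(-c3cnc(OC)cn3)c2)c2cc(-c3cn4nc(OC)sc4n3)oc2c1` gives 722 ng.h/mL. The number for compound 3 lies nearest to that of compound 1, since a 1.6-fold higher number from compound 1 to compound 3 (0.20 log units; within the scatter), and further from that of compound 2, since a 2.5-fold lower number from compound 2 to compound 3 (0.40 log units; beyond the scatter). Compound 4 `COc1cc(OCc2cccc(-c3ccc(C#N)cc3)c2)c2cc(-c3cn4nc(OC)sc4n3)oc2c1` differs from compound 3 in one place: 4-cyanophenyl in place of 5-methoxypyrazin-2-yl on an aromatic carbon. The measured steps that exchanged this same group, a 3.9-fold higher number from compound 1 to compound 2 (0.59 log units; beyond the scatter) and a 2.5-fold lower number from compound 2 to compound 3 (0.40 log units; beyond the scatter), were both modest, and none of them placed a 4-cyanophenyl group at this position, so they give only loose guidance. The most reasonable expectation is a step that stays within the usual scatter. Compound 4 is therefore expected to give 600 ng.h/mL in this assay, with a range from 200 ng.h/mL to 1800 ng.h/mL. This estimate means an expected step of a 1.2-fold lower number from compound 3 to compound 4 (0.08 log units; within the scatter) in this assay.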

Compound 4, area under the concentration-time curve: 610 ng.h/mL
The estimate for compound 4 lay 1.0-fold (0.01 log units) below the measured number, within the range that was stated.
By their numbers in this assay, from the lowest: compounds 1, 4 and 3 (each within the scatter of the next); then compound 2.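

In this assay, within the data shown here, 4-cyanophenyl is the first group at this position whose ring is of carbon only, yet its exchange for 5-methoxypyrazin-2-yl stays within the scatter (a 1.2-fold lower number from compound 3 to compound 4 (0.07 log units; within the scatter)). The same holds for its exchange for 5-(trifluoromethyl)pyridin-2-yl (a 1.3-fold higher number from compound 1 to compound 4 (0.12 log units; within the scatter)), so compounds 1, 3 and 4 cannot be told apart, even though their rings hold different numbers of nitrogen atoms. The step beyond the scatter (a 3.0-fold lower number from compound 2 to compound 4 (0.47 log units; beyond the scatter)) leaves compound 2, with its 6-methoxypyridin-3-yl group, alone above the other three, and nothing measured here accounts for this.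

On these data alone, it remains open whether the methoxy group or the ring nitrogen sets compound 2 apart, which a 4-methoxyphenyl group could help to separate. As far as these compounds go, how an amine or a carboxylic acid on this ring would read also remains unknown.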